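Fluoro to methyl on the cyclopropyl amide of compound 3

This account rests on a few compounds, and the source may have more. Where it says the series, first, only, none or still open, it means among the compounds named here.

Measured so far:
compound 1 `CC(=O)N1CC2CC(C1)N2` gives 150 nM in an assay on SH-EP1 cells for displacement of a labelled ligand from Neuronal acetylcholine receptor; alpha4/beta2 (Homo sapiens), read by scintillation counting; a higher number here means a weaker inhibitor, a lower number a stronger inhibitor
compound 2 `O=C([C@H]1C[C@@H]1F)N1CC2CC(C1)N2` gives 5.4 nM
compound 3 `O=C([C@@H]1C[C@H]1F)N1CC2CC(C1)N2` gives 1 nM

Compound 3 stands lowest of the three numbers: compound 2 sits at a 5.4-fold lower number from compound 2 to compound 3 (0.73 log units; beyond the scatter) and compound 1 at a 150-fold lower number from compound 1 to compound 3 (2.18 log units; beyond the scatter). The step from compound 2 to compound 3 runs between the two drawn stereo forms of the same amide (the fact that one of compounds 2 and 3 is drawn with a defined configuration and the other without, at the place where they differ). The large gains come with the 2-fluorocyclopropyl in place of methyl on a carbonyl carbon, seen as a 28-fold lower number from compound 1 to compound 2 (1.44 log units; beyond the scatter) and a 150-fold lower number from compound 1 to compound 3 (2.18 log units; beyond the scatter).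

Compound 4 `C[C@@H]1C[C@H]1C(=O)N1CC2CC(C1)N2` keeps the ring and the drawn configuration of compound 3 but carries methyl in place of fluoro on a saturated ring carbon. Within the data shown here, no measured step removes the fluoro while keeping the cyclopropyl. The fluoro and the ring have not been measured apart from each other. Since the whole ring change gave a 150-fold lower number from compound 1 to compound 3 (2.18 log units; beyond the scatter), part of that is expected to remain, and compound 4 is expected to give a modest rise, a 5.0-fold higher number from compound 3 to compound 4 (0.70 log units; beyond the scatter). The estimate for compound 4 in this assay is 5 nM, within 1.5 nM to 20 nM.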

Compound 4, inhibition constant: 1 nM
Estimate against measurement, compound 4: 5.0-fold (0.70 log units) above; measured number outside the range, below it.
By their numbers in this assay, from the lowest: compounds 3 and 4 (each within the scatter of the next); then compound 2; then compound 1.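

Methyl in place of fluoro on this saturated ring carbon leaves the reading unmoved, with no change at the digits printed from compound 3 to compound 4 (within the scatter), so in this drawn configuration the fluoro is not needed for the number. The earlier compounds shown here could not separate the fluoro from the ring, but the gain over the simple methyl amide survives without fluorine, with a 150-fold lower number from compound 1 to compound 4 (2.18 log units; beyond the scatter). The other drawn fluoro form also stays behind the methyl compound, with a 5.4-fold lower number from compound 2 to compound 4 (0.73 log units; beyond the scatter), and any reading of that gap as one of configuration rests on a single point: the fact that one of compounds 2 and 3 is drawn with a defined configuration and the other without, at the place where they differ.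

As far as these compounds go, whether the bare cyclopropyl amide, with hydrogen on this ring carbon, holds the number remains open, as does the effect of an ethyl, a hydroxyl or an amine there. From the compounds shown here alone, the opposite drawn form of the 2-methylcyclopropyl amide is also open, so the weight of configuration with methyl cannot be read.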